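This account rests on a few compounds, and the source may have more. Where it says the series, first, only, none or still open, it means among the compounds named here.

Measured so far:
compound 1 `Cc1cc(S(N)(=O)=O)ccc1NC(=O)COc1ccc(Cl)cc1C(O)c1ccccc1Cl`: 32000 nM
compound 2 `Cc1cc(S(N)(=O)=O)ccc1NC(=O)COc1ccc(Cl)cc1C(O)c1cccc(Cl)c1`: 33300 nM
compound 3 `Cc1cc(C)cc(C(O)c2cc(Cl)ccc2OCC(=O)Nc2ccc(S(N)(=O)=O)cc2C)c1`: 29400 nM

In an ADME assay on C8166 cells (Homo sapiens) for cytotoxicity, read by MTT assay (a lower number here means that less compound is tolerated, a higher number that more compound is tolerated), compound 1 stands second highest of the three numbers; its nearest neighbour is compound 2 a 1.0-fold higher number from compound 1 to compound 2 (0.02 log units; within the scatter) and its furthest compound 3 a 1.1-fold lower number from compound 1 to compound 3 (0.04 log units; within the scatter), both within the scatter. Compound 4 `Cc1cc(S(N)(=O)=O)ccc1NC(=O)COc1ccc(Cl)cc1C(O)c1ccc(Cl)cc1Cl` differs from compound 1 by chloro in place of hydrogen on an aromatic carbon. The measured steps all swap the aryl group on that same saturated carbon: a 1.0-fold higher number from compound 1 to compound 2 (0.02 log units; within the scatter), a 1.1-fold lower number from compound 1 to compound 3 (0.04 log units; within the scatter) and a 1.1-fold lower number from compound 2 to compound 3 (0.05 log units; within the scatter), every one within the scatter. None of them adds a second chloro to the 2-chlorophenyl, but all three show this aryl barely touching the number in this assay, so no step beyond the scatter is expected. Compound 4 is therefore estimated at 32000 nM (range 16000 nM to 60000 nM), meaning an expected step of no change at the digits printed from compound 1 to compound 4 (within the scatter).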

Compound 4, half-maximal cytotoxic concentration: 39900 nM
Compound 4: middle estimate off by 1.2-fold (0.10 log units), on the low side, and the stated range covers the measured number.
By their numbers in this assay, from the lowest: compounds 3, 1, 2 and 4 (each within the scatter of the next).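

In this assay, chloro in place of hydrogen on the 2-chlorophenyl, para to a large group, gives a 1.2-fold higher number from compound 1 to compound 4 (0.10 log units; within the scatter); a second chloro on this ring therefore leaves the number within the scatter. The swaps from the other aryl groups read the same, with a 1.2-fold higher number from compound 2 to compound 4 (0.08 log units; within the scatter) and a 1.4-fold higher number from compound 3 to compound 4 (0.13 log units; within the scatter). Nothing available bears on the cause of these steps.

As far as these compounds go, all four compounds carry only chloro or methyl on this aryl ring, so the effect of an amine or a carboxylic acid there remains open. Whether this flat reading would survive such a group is also unknown.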